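The source may report more compounds than this note shows. Statements on the series, on what has been measured and on what is new or still open speak of the compounds shown alone.

Working notes on the series. Two compounds sharing one core have been run in an assay on isolated protein for inhibition of ubiquitin carboxyl-terminal hydrolase 7 (Homo sapiens), with stated times of 30 min and 2 h; a lower number here means a stronger inhibitor, a higher number a weaker inhibitor. Compound 1 `Cn1nc2c(=O)n(CC3(O)CCN(Cc4ccc(-c5ccco5)cc4Cl)CC3)cnc2c1-c1ccc(CNCCO)cc1` gives 8.2 nM. Among the measured compounds shown here, compound 2 `Cn1nc2c(=O)n(CC3(O)CCN(Cc4ccc(-c5ccco5)cc4Cl)CC3)cnc2c1-c1ccc(OC(F)F)cc1` gives 179 nM, the highest number of the two measured so far; the only measured step, a 22-fold higher number from compound 1 to compound 2 (1.34 log units; beyond the scatter), separates it from compound 1.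

Compound 3 `CCNCc1ccc(-c2c3ncn(CC4(O)CCN(Cc5ccc(-c6ccco6)cc5Cl)CC4)c(=O)c3nn2C)cc1` is not yet measured. Relative to compound 2 the change is (ethylamino)methyl in place of difluoromethoxy on an aromatic carbon. This is the same position that the measured step concerns: there, difluoromethoxy in place of ((2-hydroxyethyl)amino)methyl raised the number by a 22-fold higher number from compound 1 to compound 2 (1.34 log units; beyond the scatter). Compound 3 puts back a group of the kind found in compound 1, (ethylamino)methyl differing from ((2-hydroxyethyl)amino)methyl only in the chain it carries, so the measured step should be largely reversed. A large step downward is therefore expected, a 15-fold lower number from compound 2 to compound 3 (1.17 log units; beyond the scatter), close to the gap between compound 2 and compound 1. For compound 3 the expected value in this assay is 12 nM, with a range from 4 nM to 40 nM.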

Compound 3, half-maximal inhibitory concentration: 15.2 nM
Compound 3: middle estimate off by 1.3-fold (0.10 log units), on the low side; measured number inside the range.
By their numbers in this assay, from the lowest: compounds 1 and 3 (each within the scatter of the next); then compound 2.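

In this assay, the large gap at this position now holds for a second nitrogen-bearing group: with (ethylamino)methyl in place of difluoromethoxy on the aromatic carbon para to a large group, there is a 12-fold lower number from compound 2 to compound 3 (1.07 log units; beyond the scatter). Compound 1 alone could not show whether that gap needed the hydroxy at the end of its chain, but removing the hydroxy gives a 1.9-fold higher number from compound 1 to compound 3 (0.27 log units; within the scatter), so in this assay the two groups cannot be told apart and the hydroxy is not required for a number in this range. No information is at hand on why either nitrogen-bearing group differs so much from difluoromethoxy.

The compounds shown compare these two amines with a single group lacking nitrogen, so they leave open whether the amine nitrogen itself matters or whether an ether chain of similar length, such as 2-methoxyethoxy, would do as well. Going by these compounds, how far this position tolerates change in the amine also remains open, whether as a primary amine, a tertiary amine such as dimethylaminomethyl, a ring amine such as piperidine, a longer chain or a carboxylic acid.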